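The source may hold more compounds than are shown below. What is called first, only, known or untested is meant among the compounds shown, and "the series" means these compounds.

Measured so far in an assay on isolated protein for inhibition of serine protease 1 (Bos taurus); a higher number here means a weaker inhibitor, a lower number a stronger inhibitor:
compound 1 `Cc1c(F)c(Oc2cccc(NS(C)(=O)=O)c2)nc(Oc2cccc(C(=N)N)c2)c1F` gives 1900 nM
compound 2 `Cc1c(F)c(Oc2cccc(OC(C)C)c2)nc(Oc2cccc(C(=N)N)c2)c1F` gives 2900 nM

Compound 2 carries the higher of the two numbers, yet the step of a 1.5-fold higher number from compound 1 to compound 2 (0.18 log units; within the scatter) lies within the scatter, so compounds 1 and 2 are not separated by these data. Compound 3 `Cc1ccc(N(C)C)cc1Oc1nc(Oc2cccc(C(=N)N)c2)c(F)c(C)c1F` differs from compound 2 by 5-(dimethylamino)-2-methylphenyl in place of 3-isopropoxyphenyl on an oxygen on an aromatic ring. Within the data shown here, the only measured step that bears on a change at this position, a 1.5-fold higher number from compound 1 to compound 2 (0.18 log units; within the scatter), was within the scatter; the step expected in this assay, a 1.2-fold lower number from compound 2 to compound 3 (0.06 log units; within the scatter), is therefore not beyond the scatter either. Compound 3 is estimated at 2500 nM, with a range from 900 nM to 7000 nM.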

Compound 3, inhibition constant: > 5000 nM
Compound 3: only a limit was reported; the forecaster's own chance of this, stated with the estimate: 5%; middle value at least 2.0-fold (0.30 log units) away from the limit.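

In this assay compound 3 is reported only as a limit, > 5000 nM. The step reads an at least 1.7-fold higher number from compound 2 to compound 3 (0.23 log units; that floor lies within the scatter), so the change on this oxygen is not shown to go beyond the scatter, yet unlike compounds 1 and 2 this compound has no upper bound on its number. The true size of the step stays unknown, and the reading rests on a single floor: the limit of > 5000 nM in this assay, at which 1 of the 3 values shown sits.

As far as these compounds go, whether the dimethylamino group or the added methyl drives the step stays open, since both enter together. From the compounds shown here alone, how a carboxylic acid on that ring would read in this assay is also open.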